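Lengthening the Amine Substituent in a Dichlorophenyl Analogue

The source may report more compounds than this note shows. Statements on the series, on what has been measured and on what is new or still open speak of the compounds shown alone.

Measured so far:
Compound 1, `CO[C@@]12CCN(C)C[C@H]1[C@H](c1ccc(Br)cc1)C(C#N)=C(N)O2`: 7900 nM
Compound 2, `CCN1CC[C@@]2(OC)OC(N)=C(C#N)[C@@H](c3ccc(Br)cc3)[C@@H]2C1`: 13200 nM
Compound 3, `CCN1CC[C@@]2(OC)OC(N)=C(C#N)[C@@H](c3ccc(Cl)cc3Cl)[C@@H]2C1`: 27100 nM

All three were tested in a functional assay on trachea (Cavia porcellus); on this read-out lower numbers stand for stronger inhibition and higher numbers for weaker inhibition. Compound 1 differs from compound 2 by methyl in place of hydrogen on a saturated chain carbon bound to an amine nitrogen in a ring, a change that gave a 1.7-fold higher number from compound 1 to compound 2 (0.22 log units; within the scatter). Compound 2 differs from compound 3 by a swap of the aryl group, which gave a 2.1-fold higher number from compound 2 to compound 3 (0.31 log units; beyond the scatter). The difference between the cores of compound 1 and compound 3 is not broken down here.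

The unmeasured compound 4, `CCCN1CC[C@@]2(OC)OC(N)=C(C#N)[C@@H](c3ccc(Cl)cc3Cl)[C@@H]2C1`, differs from compound 3 by methyl in place of hydrogen on a saturated chain carbon, two bonds along the chain from an amine nitrogen in a ring. This is the same kind of change as that from compound 1 to compound 2, but it sits one bond further out: two bonds along the chain from the ring nitrogen rather than bound to it. For compound 4 the expected step is a 1.5-fold higher number from compound 3 to compound 4 (0.17 log units; within the scatter) because the earlier change gave a 1.7-fold higher number from compound 1 to compound 2 (0.22 log units; within the scatter). Compound 4 is therefore expected to give 40000 nM, with a likely range from 15000 nM to 110000 nM.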

Compound 4, half-maximal inhibitory concentration: 35500 nM
Estimate against measurement, compound 4: 1.1-fold (0.05 log units) above; the measured number falls inside the stated range.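

In this assay, methyl in place of hydrogen on a saturated chain carbon, two bonds along the chain from an amine nitrogen in a ring, gives a 1.3-fold higher number from compound 3 to compound 4 (0.12 log units; within the scatter). Set beside the earlier step, lengthening the chain looks alike on the two cores: the same change on two cores in this assay, a 1.7-fold higher number (0.22 log units; within the scatter) from compound 1 to compound 2 and a 1.3-fold higher number (0.12 log units; within the scatter) from compound 3 to compound 4, 1.3-fold (0.11 log units) apart, within the scatter of two such steps Both steps lie within the scatter, and two pairs make no rule for the series, so neither a real effect of the added carbon nor its transfer to further cores is shown.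

The compounds shown leave open whether a longer chain, such as butyl, on the amine nitrogen would move the number beyond the scatter. Also open, going by these compounds, is how a propyl chain behaves alongside 4-bromophenyl.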